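Carboxylic acid to tetrazole on a shared core

The source may hold more compounds than are shown below. What is called first, only, known or untested is meant among the compounds shown, and "the series" means these compounds.

Among the compounds with values here, compound 1 `CCCc1c(COc2ccc(C(=O)CCCC(=O)O)cc2)ccc(C(C)=O)c1O` is the only compound here with a single number; in a functional assay on ileum (Cavia porcellus) with cysteinyl leukotriene receptor (Homo sapiens) as the target (a higher number here means a more potent compound, by a factor of ten per unit of this negative logarithm, a lower number a less potent compound), compound 1 gives 6.81, alongside one further entry that carries no single number. Compound 2 `CCc1c(COc2ccc(C(=O)CC(C)(C)CC(=O)O)cc2)ccc(C(C)=O)c1O` in this assay gives 7.46; 7.6 (2 entries), which stands above the value of compound 1. Compound 3 `CCCc1c(COc2ccc(C(=O)CC(C)(C)Cc3nnn[nH]3)cc2)ccc(C(C)=O)c1O` differs from compound 1 by 1-((1H-tetrazol-5-yl)methyl)-1-methylethyl in place of 2-carboxyethyl on a saturated chain carbon bound to a carbonyl carbon. Within the data shown here, no measured pair shows this exact change, and the size of the step is therefore open. Compound 3 is expected to gain over compound 1 by a number 0.79 log units higher from compound 1 to compound 3 (beyond the scatter) in this assay, an estimate of 7.6 with a range from 7 to 8.2.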

Compound 3, negative logarithm of the antagonist equilibrium constant: 7.86
For compound 3 the middle estimate is 0.26 log units below the measured one; measured number inside the range.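

In this assay, 1-((1H-tetrazol-5-yl)methyl)-1-methylethyl in place of 2-carboxyethyl on a saturated chain carbon bound to a carbonyl carbon now has a measured size: a number 1.05 log units higher from compound 1 to compound 3 (beyond the scatter). This step is wider than the spread of repeat entries on a single compound: the several entries of compound 2 in this assay, 7.46; 7.6 (2 entries)

The entering group differs from the leaving one in both its branching and its tetrazole, and the compounds shown do not separate the two. Neither 2-(1H-tetrazol-5-yl)ethyl nor 2-carboxy-1,1-dimethylethyl on the core of compound 1 is among them.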